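Methoxy to Hydroxymethyl: Expectations for Compound 3

The source may hold more compounds than are shown below. What is called first, only, known or untested is meant among the compounds shown, and "the series" means these compounds.

Two compounds share a core in which a benzyloxy group carries a halogen. Compound 1 `COc1cc(=O)oc2cc(OCc3cccc(F)c3)ccc12` bears fluoro and in an assay on isolated protein (strain Sprague-Dawley) for inhibition of Amine oxidase [flavin-containing] B (Rattus norvegicus), read by spectrophotometry, with a stated time of 5 min (a lower number here means a stronger inhibitor, a higher number a weaker inhibitor), compound 1 gives 36.3 nM. Compound 2 `COc1cc(=O)oc2cc(OCc3cccc(Br)c3)ccc12` bears bromo instead and in this assay compound 2 gives 5.75 nM. Going by the values given here, the single measured step, a 6.3-fold lower number from compound 1 to compound 2 (0.80 log units; beyond the scatter), is the only comparison available, and it leaves compound 2 with the lowest of the two numbers, with compound 1 the nearest and clearly weaker.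

Compound 3 `O=c1cc(CO)c2ccc(OCc3cccc(Br)c3)cc2o1` keeps the bromo-substituted benzyloxy group and differs from compound 2 only in hydroxymethyl in place of methoxy on an aromatic carbon. Among the compounds with values here, no measured step touches this part of the molecule: the one step measured concerns the halogen on the benzyl ring, not the small group on the fused ring, so there is no precedent here for the size or direction of the change.

Compound 3 is therefore expected to stay in the same general range as compound 2, with a step of a 2.6-fold higher number from compound 2 to compound 3 (0.42 log units; beyond the scatter) representing an estimated mild weakening. In this assay compound 3 is expected to give 15 nM, within a range from 3 nM to 80 nM.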

Compound 3, half-maximal inhibitory concentration: 14.1 nM
Estimate against measurement, compound 3: 1.1-fold (0.03 log units) above, and the stated range covers the measured number.
By their numbers in this assay, from the lowest: compound 2; then compound 3; then compound 1.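

In this assay, going by these compounds alone, hydroxymethyl in place of methoxy on the aromatic carbon opposite the ring oxygen gives a 2.5-fold higher number from compound 2 to compound 3 (0.39 log units; beyond the scatter), the first measured change at this position, and it shows that the number here responds to more than the halogen on the benzyl ring. The two groups have the same heavy atoms, one carbon and one oxygen, joined differently, and hydroxymethyl has one hydrogen-bond donor where methoxy has none, so a rearrangement that leaves the atoms unchanged is enough to move the number beyond the usual scatter. Nothing available explains why this step has its direction or size.

Within the data shown here, with only this one pair at the position, it remains open whether the step goes with the hydroxyl hydrogen or with the way the oxygen is attached, and how an aminomethyl group, a carboxylic acid or a longer chain such as ethoxy would read at the same carbon. Going by these compounds, it is also open whether the step would keep its size with fluoro in place of bromo on the benzyloxy group.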